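One Stereocentre Turned: From Compound 1 to Compound 3

The compounds below may be only part of what the source reports. "The series", "measured", "known", "first", "only" and "open" are said of these compounds alone.

Compound 1 `COc1cc([C@H]2C=CC[C@@H]3C(=O)OC[C@@H]32)cc(OC)c1OC` was examined in a functional assay on P815 cells (Mus musculus) for inhibition, read by microscopy and colony formation, with a stated time of 7 days, tested at 0.5 uM (on this read-out lower numbers stand for a weaker effect and higher numbers for a stronger effect at the one concentration tested), where compound 1 gives 81%. Alongside it stands compound 2 `COc1cc([C@H]2C=CC[C@@H]3COC(=O)[C@H]32)cc(OC)c1OC`, which in this assay gives 84%, a number lying within the usual scatter of the value for compound 1, so the two cannot be told apart on this read-out and neither can be called the more active. Compound 3 `COc1cc([C@H]2C=CC[C@@H]3C(=O)OC[C@H]32)cc(OC)c1OC` has not yet been measured. Compared with compound 1, (the two compounds have the same atoms and bonds and differ only in configuration as drawn: 1 of 3 stereo elements differ; a stereocentre at a saturated ring carbon is drawn R in compound 1 and S in compound 3). Within the data shown here, no pair of measured compounds separated by a single change is available, so the size of such a step cannot be read from these data. Because compound 1 gives 81% and compound 2 gives 84%, both high, the author expects the step of a number 9 percentage points lower from compound 1 to compound 3 (within the scatter) to be modest, leaning toward a slight fall. Compound 3 is therefore estimated to give about 72% in this assay, within a range from 35% to 95%.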

Compound 3, a percentage reported as activity, at one concentration (the size of the read-out at that concentration, not a potency): 89%
The estimate for compound 3 lay 17 percentage points below the measured number, and the stated range covers the measured number.
By their numbers in this assay, from the lowest: compounds 1, 2 and 3 (each within the scatter of the next).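

Among these compounds, compounds 1 and 3 give the first single-change step in this set, and it reads cleanly as a matter of configuration at one saturated ring carbon: the fact that compounds 1 and 3 differ only in the configuration as drawn. In this assay, turning that stereocentre from R to S gives a number 8 percentage points higher from compound 1 to compound 3 (within the scatter), so the two compounds cannot be told apart on this read-out. At the one concentration tested, the configuration at this position therefore shows no effect beyond the scatter, although a read-out at one concentration is not a potency.

From the compounds shown here alone, whether the same holds at a lower concentration, where a difference between compound 1 and compound 3 might appear, remains open. Also open, going by these compounds, are the other two stereo elements, and how the shared core would respond to a new group such as a hydroxyl or an amine.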